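The compounds below may be only part of what the source reports. "The series", "measured", "known", "first", "only" and "open" are said of these compounds alone.

Measured so far in a functional assay on HUVEC cells (Homo sapiens) for antiproliferative activity, read by MTT assay, with a stated time of 24 h; on this read-out higher numbers stand for weaker inhibition and lower numbers for stronger inhibition:
- compound 1 `COc1cc(OC)c(-c2coc3cc(OCc4ccccc4F)ccc3c2=O)cc1OC`: 4300 nM
- compound 2 `COc1cc(OC)c(-c2coc3cc(OCc4cccc(F)c4)ccc3c2=O)cc1OC`: 5300 nM

In this assay, going by the values given here, compound 2 at 5300 nM stands level with compound 1, the only other measured compound. The step between them is a 1.2-fold higher number from compound 1 to compound 2 (0.09 log units; within the scatter), which lies within the scatter.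

Compound 3 `COc1cc(OC)c(-c2coc3cc(OCc4ccc(Cl)cc4)ccc3c2=O)cc1OC` has not yet been measured. It keeps the core of compound 2 and differs in one place: 4-chlorophenyl in place of 3-fluorophenyl on a saturated chain carbon bound to an oxygen on an aromatic ring. In words, 4-chlorophenyl stands in place of 3-fluorophenyl on a saturated chain carbon bound to an oxygen on an aromatic ring.

Among the compounds with values here, only one measured step bears on this change, the exchange of 2-fluorophenyl for 3-fluorophenyl at the same place, and it gives a 1.2-fold higher number from compound 1 to compound 2 (0.09 log units; within the scatter). Neither measured compound carries 4-chlorophenyl, so the data show no direct effect of that group and give no direction for the change. The expected outcome is therefore no step beyond the scatter, and the estimated step is a 1.2-fold lower number from compound 2 to compound 3 (0.07 log units; within the scatter). For compound 3 the estimated value is 4500 nM, with an expected range from 1900 nM to 10500 nM.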

Compound 3, half-maximal inhibitory concentration: 4400 nM
The estimate for compound 3 lay 1.0-fold (0.01 log units) above the measured number; the range from low to high includes it.
By their numbers in this assay, from the lowest: compounds 1, 3 and 2 (each within the scatter of the next).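

In this assay the exchange of 3-fluorophenyl for 4-chlorophenyl on a saturated chain carbon bound to an oxygen on an aromatic ring gives a 1.2-fold lower number from compound 2 to compound 3 (0.08 log units; within the scatter) and the exchange of 2-fluorophenyl for 4-chlorophenyl at that place gives a 1.0-fold higher number from compound 1 to compound 3 (0.01 log units; within the scatter) and so neither step leaves the scatter. The earlier pair showed only that fluorine could occupy two places on the phenyl ring without a readable difference, whereas compound 3 shows the same for a change of both the halogen and its place, and all three compounds stand level on this read-out. Because the halogen and its place change together in these steps, the two changes cannot be told apart here, and nothing measured alongside these numbers accounts for the lack of a difference.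

Going by these compounds, all three compounds carry a halogen-bearing phenyl ring at this position, so it remains open whether the number would move with a group of another kind there, such as an amine, a carboxylic acid or a longer chain. On these data alone, it also remains open whether chlorine on the phenyl ring at the 2- or 3-position, or a phenyl ring with no halogen, would stay level with these compounds.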